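The source may hold more compounds than are shown below. What is called first, only, known or untested is meant among the compounds shown, and "the series" means these compounds.

Compound 3 `CCOC(=O)COc1ccc2c(=O)c(-c3ccc(O)cc3)coc2c1` gives 130 nM in an assay (Cricetulus griseus) for inhibition of aldehyde dehydrogenase, mitochondrial (Homo sapiens) (a higher number here means a weaker inhibitor, a lower number a stronger inhibitor), and stands second highest of the three numbers seen so far. Its nearest neighbour is compound 2 `O=C(O)CCCCOc1ccc2c(=O)c(-c3ccc(O)cc3)coc2c1` at 100 nM, and a 1.3-fold higher number from compound 2 to compound 3 (0.11 log units; within the scatter), so the two cannot be told apart. Compound 1 `CCCCCCOc1ccc2c(=O)c(-c3ccc(O)cc3)coc2c1` at 1500 nM is far away: a 15-fold lower number from compound 1 to compound 2 (1.18 log units; beyond the scatter) and a 12-fold lower number from compound 1 to compound 3 (1.06 log units; beyond the scatter). Compound 4 `CC(Oc1ccc2c(=O)c(-c3ccc(O)cc3)coc2c1)C(=O)O` arises from compound 3 by 1-carboxyethyl in place of (ethoxycarbonyl)methyl on an oxygen on an aromatic ring. Within the data shown here, the steps that bear on this are the exchange of an ester for an acid, which gave a 1.3-fold higher number from compound 2 to compound 3 (0.11 log units; within the scatter), and the arrival of a carboxy group, which gave a 15-fold lower number from compound 1 to compound 2 (1.18 log units; beyond the scatter). Since acid and ester behaved alike, no step beyond the scatter is expected in this assay, a 1.1-fold lower number from compound 3 to compound 4 (0.03 log units; within the scatter). Compound 4 is therefore estimated at 120 nM, between 45 nM and 320 nM.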

Compound 4, half-maximal inhibitory concentration: 2500 nM
Beside the measured number, compound 4's estimate is 21-fold (1.32 log units) below it; measured number outside the range, above it.
By their numbers in this assay, from the lowest: compounds 2 and 3 (each within the scatter of the next); then compounds 1 and 4 (each within the scatter of the next).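

Carrying a carboxy group on this oxygen does not by itself keep the number low: 1-carboxyethyl in place of 4-carboxybutyl is a large loss (a 25-fold higher number from compound 2 to compound 4 (1.40 log units; beyond the scatter)). Replacing (ethoxycarbonyl)methyl with 1-carboxyethyl is also a large loss (a 19-fold higher number from compound 3 to compound 4 (1.28 log units; beyond the scatter)), while the result cannot be told apart from the hexyl ether (a 1.7-fold higher number from compound 1 to compound 4 (0.22 log units; within the scatter)).

Carboxymethyl, the same acid without the extra methyl on the chain, would show whether that methyl matters or the short acid chain itself. Nothing measured here explains the loss.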